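Aryl replacement on the enone core of compound 1

The source may report more compounds than this note shows. Statements on the series, on what has been measured and on what is new or still open speak of the compounds shown alone.

Measured compounds:
compound 1 `CCOc1ccc(/C=C(\C(=O)c2ccc(Cl)cc2)S(=O)(=O)Cc2ccc(C)cc2)cc1OC` — 10000 nM
compound 2 `CCOc1ccc(/C=C(\C(=O)c2ccc(Cl)cc2)S(=O)(=O)Cc2ccccc2Cl)cc1OC` — 10000 nM
compound 3 `CCOc1ccc(/C=C(/SCc2ccc(C)cc2)C(=O)c2ccc(Cl)cc2)cc1OC` — 25000 nM

All three were measured in a functional assay on DU-145 cells (Homo sapiens) for inhibition, read by trypan blue exclusion, with a stated time of 96 h; on this read-out lower numbers stand for stronger inhibition of growth and higher numbers for weaker inhibition of growth. Compound 1 stands level with compound 2 at the digits recorded, and the two together give the lowest numbers of the three; compound 3 gives the highest. The step of no change at the digits printed from compound 1 to compound 2 (within the scatter) shows that exchanging the benzyl group on the sulfonyl leaves the number unchanged, while a 2.5-fold higher number from compound 1 to compound 3 (0.40 log units; beyond the scatter) and a 2.5-fold higher number from compound 2 to compound 3 (0.40 log units; beyond the scatter) show a modest rise when the sulfonyl becomes a sulfanyl.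

Compound 4 `COc1ccccc1/C=C(\C(=O)c1ccc(Cl)cc1)S(=O)(=O)Cc1ccc(C)cc1` differs from compound 1 in a third place: 2-methoxyphenyl in place of 4-ethoxy-3-methoxyphenyl on a double-bonded chain carbon bound to a double-bonded chain carbon. Among the compounds with values here, no measured step touches this aryl group, so nothing here bears on it directly. Within the data shown here, the only guide is that a change elsewhere on the shared core, the benzyl exchange, left the number unchanged, whereas the sulfur oxidation state moved it modestly. The expected step of a 1.2-fold higher number from compound 1 to compound 4 (0.08 log units; within the scatter) is therefore small and uncertain in direction. Compound 4 is estimated at 12000 nM, within a range of 4000 nM to 40000 nM.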

Compound 4, concentration for 50% growth inhibition: 10000 nM
For compound 4 the middle estimate is 1.2-fold (0.08 log units) above the measured one; the range from low to high includes it.
By their numbers in this assay, from the lowest: compounds 1, 2 and 4 (each within the scatter of the next); then compound 3.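

In this assay, the first read on this position shows that the aryl group on the double-bonded chain carbon can be exchanged, with 2-methoxyphenyl in place of 4-ethoxy-3-methoxyphenyl giving no change at the digits printed from compound 1 to compound 4 (within the scatter). The change takes the group from 11 heavy atoms to 8 and from 2 hydrogen-bond acceptors to 1, so neither the 4-ethoxy-3-methoxyphenyl group as a whole nor its full set of oxygens is needed to hold the number at this level. No evidence is available to explain this outcome.

The compounds shown leave open whether an amine or a carboxylic acid on this aryl ring would move the number. They also leave open whether the sulfanyl step seen with 4-ethoxy-3-methoxyphenyl would recur with 2-methoxyphenyl.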